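The source may report more compounds than this note shows. Statements on the series, on what has been measured and on what is new or still open speak of the compounds shown alone.

Working notes on the series. Compound 1 `Cc1cccc(-c2n[nH]cc2N2CCCNCC2)c1` and compound 2 `Fc1cccc(-c2n[nH]cc2N2CCCNCC2)c1` share one core; compound 3 `Fc1ccc(-c2n[nH]cc2N2CCNCC2)cc1` and compound 4 `Cc1ccc(-c2n[nH]cc2N2CCNCC2)cc1` share another, and the difference between the two cores is not broken down here. In an assay on isolated protein for binding affinity to 5-hydroxytryptamine receptor 3A (Homo sapiens) (on this read-out higher numbers stand for weaker inhibition and lower numbers for stronger inhibition), compound 1 gives 816 nM. In this assay compound 2 gives 656 nM. In this assay compound 3 returns only a limit of the assay, > 10000 nM. Compound 4 has not yet been measured in this assay.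

The measured pair differs by methyl in place of fluoro on an aromatic carbon, and that change made a 1.2-fold higher number from compound 2 to compound 1 (0.09 log units; within the scatter). Compound 4 arises from compound 3 by methyl in place of fluoro on an aromatic carbon, the same kind of change; the place is not identical, being meta to a large group in the first pair and para to a large group in the second.

Going by the values given here, since the one measured instance of this change stayed within the scatter, compound 4 is expected to remain close to where compound 3 stands, and the step that the limit leaves unreadable from compound 3 to compound 4 is expected to be small. Because compound 3 sits at the limit of > 10000 nM in this assay, at which 1 of the 3 values shown sits, a fresh limit is also plausible for compound 4. Compound 4 is therefore estimated at 15000 nM, with an expected range from 5000 nM to 50000 nM.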

Compound 4, inhibition constant: > 10000 nM
Compound 4: no number, only a limit (the forecaster's own chance of this, stated with the estimate: 70%); the middle value lies beyond the limit too.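

No step can be read between compound 3 and compound 4, since each returns only a limit of the assay in this assay: the limit of > 10000 nM in this assay, at which 2 of the 4 values shown sit.

The compounds shown leave open how far compound 3 and compound 4 lie beyond that limit, and whether methyl in place of fluoro, para to a large group, changes the read-out at all.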